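Sulfonyl aryl variation on a quinolone core: notes

The source may hold more compounds than are shown below. What is called first, only, known or untested is meant among the compounds shown, and "the series" means these compounds.

Measured so far:
- Compound 1 `COc1ccc(-c2cc(=O)c3c(OC)cc(OC)cc3n2S(=O)(=O)c2cccc([N+](=O)[O-])c2)cc1`: in a functional assay on KOPN-8 cells (Homo sapiens) for antiproliferative activity, with a stated time of 72 h (a lower number here means that less compound is needed, a higher number that more compound is needed for the effect), compound 1 gives > 39600 nM, a limit of the assay.
- Compound 2 `COc1ccc(-c2cc(=O)c3c(OC)cc(OC)cc3n2S(=O)(=O)c2ccc(F)cc2)cc1`: in this assay compound 2 gives > 65500 nM, also a limit of the assay.

Compound 2 thus stands at a limit only; no number is known for it in this assay, and the same holds for compound 1, whose value is likewise a limit (the limit of > 39600 nM in this assay, at which 1 of the 2 values shown sits, (the limit of > 65500 nM in this assay, at which 1 of the 2 values shown sits)). Going by the values given here, the only measured step, a step that the two limits leave unreadable from compound 1 to compound 2, cannot be read from two limits.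

The next compound, compound 3 `COc1ccc(-c2cc(=O)c3c(OC)cc(OC)cc3n2S(=O)(=O)c2cc(F)c(F)c(F)c2)cc1`, differs from compound 2 in one place: 3,4,5-trifluorophenyl in place of 4-fluorophenyl on a sulfonyl sulfur. The measured step that bears on it, from compound 1 to compound 2, gave no readable size, so it sets no expectation for direction or magnitude; only the shared outcome of both compounds, a limit each time, is available. On that basis the step from compound 2 to compound 3 is estimated as a step that the limit leaves unreadable from compound 2 to compound 3, with no change beyond the scatter expected. For compound 3 the expected value in this assay is 100000 nM, in a range from 30000 nM to 300000 nM, most likely reported again as a limit.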

Compound 3, half-maximal effective concentration: > 65500 nM
Compound 3: only a limit was reported; the forecaster's own chance of this, stated with the estimate: 85%; the middle value does not contradict the limit.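

In this assay compound 3 gives > 65500 nM, again a limit of the assay. Going by these compounds alone, with compound 1, compound 2 and compound 3 all standing at limits, no step among them can be read. The compounds shown leave open what number any of these sulfonyl aryl groups on the shared core would give in this assay, and how far those numbers would differ.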